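A few compounds are considered here, and "the series" means these few. Any claim that something is new, unique, unknown or untested is made for them only; others in the source may bear on it.

The measured compounds:

Compound 1, `COc1ccc(CNc2nc([Se]C)nc3ccccc23)cc1`, in an ADME assay on BEAS-2B cells (Homo sapiens) for cytotoxicity, read by MTT assay, with a stated time of 72 h (on this read-out lower numbers stand for stronger inhibition of growth and higher numbers for weaker inhibition of growth), gives > 100000 nM, which is a limit of the assay rather than a number.
Compound 2, `Sc1nc(NCc2ccccc2)c2ccccc2n1`, in this assay gives 66300 nM.
Compound 3, `COc1ccc(CNc2nc(SC)nc3ccccc23)cc1`, in this assay gives 21700 nM.

Compound 3 holds the lowest of the two real numbers in this assay; compound 2 sits at a higher number, beyond the scatter, and compound 1 contributes only a limit (the limit of > 100000 nM in this assay, at which 1 of the 3 values shown sits). Within the data shown here, the one step measured between neighbouring structures, an at least 4.6-fold lower number from compound 1 to compound 3 (0.66 log units; beyond the scatter), concerns the exchange of selenium for sulfur and does not touch the methyl on the sulfur.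

Compound 4, `COc1ccc(CNc2nc(S)nc3ccccc23)cc1`, differs from compound 3 by hydrogen in place of methyl on a sulfur. Among the measured compounds shown here, no measured step addresses this change directly. Compound 2, which also carries a free sulfanyl but lacks the methoxy group, shows a higher number than compound 3, yet the two differ in two places, so only their two values can be compared. The expectation for compound 4 in this assay is therefore a modest rise, a 2.3-fold higher number from compound 3 to compound 4 (0.36 log units; beyond the scatter), with the real possibility that the assay returns only a limit. Compound 4 is estimated at 50000 nM, within 20000 nM to 130000 nM.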

Compound 4, concentration for 50% growth inhibition: 6130 nM
Estimate against measurement, compound 4: 8.2-fold (0.91 log units) above; the whole stated range lies above it.
By their numbers in this assay, from the lowest: compound 4; then compound 3; then compound 2. At a limit, above all of these: compound 1.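

Taking the methyl off the sulfur does not weaken the effect on these cells in this assay but strengthens it, with a 3.5-fold lower number from compound 3 to compound 4 (0.55 log units; beyond the scatter) as the first measured change at the sulfur itself, so methylsulfanyl to sulfanyl moves the number down, beyond the scatter. With the free sulfanyl held constant, methoxy in place of hydrogen on an aromatic carbon gives an 11-fold lower number from compound 2 to compound 4 (1.03 log units; beyond the scatter) and so isolates the methoxy group as a large contributor in this series, which the earlier comparison of two compounds differing in two places could not do. The exchange of the selenium-bearing group for a lone sulfur gives an at least 16-fold lower number from compound 1 to compound 4 (1.21 log units; beyond the scatter), a bound rather than an exact size, since one end of that step is a limit of the assay: the limit of > 100000 nM in this assay, at which 1 of the 4 values shown sits.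

The compounds shown leave open how a longer chain on the sulfur, such as ethyl, or a chain ending in a carboxylic acid would read in this assay. They also leave open whether an amine or a fluorine in place of the methoxy group would give a step of similar size.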